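This account rests on a few compounds, and the source may have more. Where it says the series, first, only, none or still open, it means among the compounds named here.

Compound 1 `Cc1ccc(Cn2ccc3nc(-c4ccccc4)nc-3c2)cc1` shares its core with two measured relatives, compound 2 `Ic1ccc(Cn2ccc3nc(-c4ccccc4)nc-3c2)cc1` and compound 3 `CCC(CC)Cn1ccc2nc(-c3ccccc3)nc-2c1`. In an ADME assay on MDBK cells (Bos taurus) for cytotoxicity (a higher number here means that more compound is tolerated, a lower number that less compound is tolerated), compound 1 gives > 100000 nM, which is a limit of the assay rather than a number. Compound 1 thus sits at the limit of > 100000 nM in this assay, at which 2 of the 3 values shown sit. Compound 2 gives 22000 nM in this assay. Compound 3 gives > 100000 nM in this assay, again a limit. Putting iodo in place of methyl gave an at least 4.5-fold lower number from compound 1 to compound 2 (0.65 log units; beyond the scatter); exchanging 4-iodophenyl for pentan-3-yl gave an at least 4.5-fold higher number from compound 2 to compound 3 (0.65 log units; beyond the scatter), while exchanging 4-methylphenyl for pentan-3-yl gave a step that the two limits leave unreadable from compound 1 to compound 3. The unmeasured compound 4 `CC(C)N(CCn1ccc2nc(-c3ccccc3)nc-2c1)C(C)C` differs from compound 1 in that same place: (diisopropylamino)methyl in place of 4-methylphenyl on a saturated chain carbon bound to an aromatic nitrogen. Of the measured steps, those ending at compound 3 bear on it: each also replaces a substituted phenyl at this place with a saturated chain, and compound 3 stays at the limit. No step beyond the scatter is therefore expected, and compound 4 is expected to remain at the limit as well. The estimated step is an at least 1.1-fold lower number from compound 1 to compound 4 (0.04 log units; that floor lies within the scatter). Compound 4 is estimated at 90000 nM, between 25000 nM and 200000 nM, most likely reported only as a limit.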

Compound 4, half-maximal cytotoxic concentration: > 100000 nM
Compound 4 was reported as a limit; the forecaster's own chance of this, stated with the estimate: 60%; at least 1.1-fold (0.04 log units) between middle value and limit.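

In this assay compound 4 gives > 100000 nM, which is a limit of the assay and not a number. Unlike the other groups shown at this place, (diisopropylamino)methyl holds a nitrogen and a hydrogen-bond acceptor, and placing it on the saturated chain carbon bound to an aromatic nitrogen still gives an at least 4.5-fold higher number from compound 2 to compound 4 (0.65 log units; beyond the scatter), so a nitrogen-bearing chain here does not bring this compound down to the level of the iodo compound. The steps to compound 4 from compound 1 and from compound 3 join two limits and cannot be read, and the values now gather at a single point: the limit of > 100000 nM in this assay, at which 3 of the 4 values shown sit.

As far as these compounds go, with so many values at that limit, the groups at this place cannot be ranked against one another, and it remains open whether a carboxylic acid or a primary amine on the chain would also stay there. From the compounds shown here alone, compound 2 alone gives a readable number, so it also remains open whether bromo or chloro in place of its iodo would lower the number in the same way.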